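A few compounds are considered here, and "the series" means these few. Any claim that something is new, unique, unknown or untested is made for them only; others in the source may bear on it.

Compound 1, `Nc1nc(-c2ccc(Cl)cc2)c(CC(=O)O)s1`: in an in vitro assay on HEK385-7 cells for displacement of a labelled ligand from prostaglandin D2 receptor 2 (Homo sapiens) (a lower number here means a stronger inhibitor, a higher number a weaker inhibitor), compound 1 gives > 100000 nM, which is a limit of the assay and not a number.
Compound 2, `CCC(c1ccccc1)c1nc(-c2ccc(Cl)cc2)c(CC(=O)O)s1`: in this assay compound 2 gives 190 nM.
Compound 3, `O=C(O)Cc1sc(C(c2ccc(F)cc2)c2ccc(F)cc2)nc1-c1ccccc1`: in this assay compound 3 gives 16 nM.

Compound 3 holds the lowest of the two numbers that have been obtained. Its nearest neighbour is compound 2, whose number is higher by a gap that lies beyond the usual scatter of such measurements. The value of compound 1 is the limit of > 100000 nM in this assay, at which 1 of the 3 values shown sits.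

The next compound, compound 4, `O=C(O)Cc1sc(C(c2ccc(F)cc2)c2ccc(F)cc2)nc1-c1cc(F)nc(F)c1`, differs from compound 3 in one place: 2,6-difluoropyridin-4-yl in place of phenyl on an aromatic carbon. Among the measured compounds shown here, no pair of measured compounds isolates a change of this kind, so the expectation rests on the change alone and on where compound 3 stands.

The step of a 1.6-fold higher number from compound 3 to compound 4 (0.19 log units; within the scatter) is expected to be small, a modest rise in the number at most, and may well stay within the scatter. Compound 4 is therefore estimated at 25 nM in this assay. For compound 4 the expected range runs from 8 nM to 80 nM.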

Compound 4, half-maximal inhibitory concentration: 5.4 nM
Estimate against measurement, compound 4: 4.6-fold (0.67 log units) above, outside the stated range (below it).
By their numbers in this assay, from the lowest: compound 4; then compound 3; then compound 2. At a limit, above all of these: compound 1.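

Among the compounds shown here, compound 3 and compound 4 are the first pair that differ only at the aromatic carbon next to the ring nitrogen. Replacing phenyl with 2,6-difluoropyridin-4-yl there gives a 3.0-fold lower number from compound 3 to compound 4 (0.47 log units; beyond the scatter) in this assay and shows that this position takes a ring with a hetero atom and two fluorines without any loss, and with a gain beyond the scatter. Nothing measured in this set bears on the cause of that gain.

For the compounds shown here, the single step does not show whether the ring nitrogen, the two fluorines or both together account for the change, and a pyridinyl group without fluorine or a phenyl group with two fluorines at this position would separate them. Going by these compounds, how an amine or a methoxy group in place of those fluorines would read also remains open.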